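Changing the aryl group on the sulfonyl sulfur

This account rests on a few compounds, and the source may have more. Where it says the series, first, only, none or still open, it means among the compounds named here.

Measured compounds:
compound 1, `Cc1cc(Nc2ccc(F)cc2)nc(Nc2ccc(NS(=O)(=O)c3ccc(C(F)(F)F)cc3)cc2)n1`, 18000 nM
compound 2, `Cc1cc(Nc2ccc(F)cc2)nc(Nc2ccc(NS(=O)(=O)c3ccccc3OC(F)(F)F)cc2)n1`, > 50000 nM

In a functional assay on MCF7 cells (Homo sapiens) for antiproliferative activity, read by MTT assay (on this read-out higher numbers stand for weaker inhibition and lower numbers for stronger inhibition), compound 1 gives 18000 nM. For compound 2 this assay reports only a limit, > 50000 nM, so its true value is not known as a number. Going by the values given here, the step of an at least 2.7-fold higher number from compound 1 to compound 2 (0.44 log units; beyond the scatter) is the only measured change, and it moved the number in the weaker direction; the size is known only as a lower bound because of the limit of > 50000 nM in this assay, at which 1 of the 2 values shown sits.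

Compound 3, `COc1cc(C)cc(Cl)c1S(=O)(=O)Nc1ccc(Nc2nc(C)cc(Nc3ccc(F)cc3)n2)cc1`, has not been measured. It differs from compound 2 by 2-chloro-6-methoxy-4-methylphenyl in place of 2-(trifluoromethoxy)phenyl on a sulfonyl sulfur. Among the compounds with values here, no measured step involves this entering group, so the one step available says only that exchanging the aryl group on the sulfonyl sulfur can shift the number by at least a modest amount. Compound 3 is therefore expected to stay in the weak range, with the estimate 40000 nM, between 10000 nM and 150000 nM. The expected step is an at least 1.2-fold lower number from compound 2 to compound 3 (0.09 log units; that floor lies within the scatter), which may well mean another limit rather than a number.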

Compound 3, half-maximal inhibitory concentration: > 50000 nM
Compound 3: only a limit was reported; the forecaster's own chance of this, stated with the estimate: 50%; at least 1.2-fold (0.09 log units) between middle value and limit.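

Replacing 4-(trifluoromethyl)phenyl with 2-chloro-6-methoxy-4-methylphenyl on the sulfonyl sulfur gives an at least 2.7-fold higher number from compound 1 to compound 3 (0.44 log units; beyond the scatter), so a second, differently substituted aryl group also ends up on the weak side in this assay. Compound 3 gives a limit of the assay, > 50000 nM, and not a number. The step from compound 2 to compound 3 cannot be read, because both compounds stop at the same limit: the limit of > 50000 nM in this assay, at which 2 of the 3 values shown sit.

On these data alone, only compound 1 has a true number, so the real distance of compound 2 and compound 3 from it remains unknown, as does their order. Also open, as far as these compounds go, is whether a plain phenyl, or a phenyl carrying a nitrile or a carboxylic acid, on the sulfonyl sulfur would keep a measurable value in this assay.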